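Swapping the Ring on the Thiocarbonyl of Compound 2

A few compounds are considered here, and "the series" means these few. Any claim that something is new, unique, unknown or untested is made for them only; others in the source may bear on it.

Compound 2 `N/C(=N\NC(=S)N1CCOCC1)c1ccc(F)cn1` was tested in a functional assay on A-375 cells (Homo sapiens) for cytotoxicity, read by MTT assay, with a stated time of 72 h (a higher number here means a weaker inhibitor, a lower number a stronger inhibitor), where compound 2 gives 1500 nM. Within the data shown here, this is the highest of the three numbers measured so far. Compound 1 `Cc1ccnc(/C(N)=N/NC(=S)N2CCCC2)c1` gives 720 nM in this assay, and compound 3 `N/C(=N\NC(=S)N1CCOCC1)c1ccccn1` gives 680 nM. Among the measured compounds shown here, the only step between two compounds that differ in a single place is a 2.2-fold lower number from compound 2 to compound 3 (0.34 log units; beyond the scatter), which puts hydrogen in place of fluoro on an aromatic carbon.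

The unmeasured compound 4 `N/C(=N\NC(=S)N1CCCC1)c1ccc(F)cn1` differs from compound 2 by pyrrolidin-1-yl in place of morpholin-4-yl on a thiocarbonyl carbon. For the measured compounds named here, no measured step isolates this change: compound 1 carries pyrrolidin-1-yl and compound 3 carries morpholin-4-yl, but the two also differ elsewhere, and in this assay compound 1 gives 720 nM while compound 3 gives 680 nM, two numbers close to each other. With nothing in the data pointing clearly either way, the expected step is a 1.4-fold lower number from compound 2 to compound 4 (0.13 log units; within the scatter), within the scatter. Compound 4 is therefore expected to give about 1100 nM in this assay, with a range from 500 nM to 2500 nM.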

Compound 4, half-maximal inhibitory concentration: 860 nM
For compound 4 the middle estimate is 1.3-fold (0.11 log units) above the measured one; the measured number falls inside the stated range.
By their numbers in this assay, from the lowest: compounds 3, 1, 4 and 2 (each within the scatter of the next, the first and the last beyond it).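

Among these compounds, with the fluoro-bearing core held fixed, this assay shows a 1.7-fold lower number from compound 2 to compound 4 (0.24 log units; within the scatter), and this is the first step that isolates the ring on the thiocarbonyl carbon. Going from a six-membered ring with 2 hetero atoms to a five-membered ring with 1 hetero atom, and so giving up the hydrogen-bond acceptor of morpholin-4-yl, leaves the number within the usual scatter, so on this core the position tolerates the swap. Nothing measured here bears on why the exchange of rings shifts the number so little.

As far as these compounds go, whether the swap reads the same on the core of compound 3, which carries hydrogen in place of fluoro, stays open. So does what a piperidin-1-yl ring or an open-chain dimethylamino group would give on the same thiocarbonyl carbon.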